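Dropping One Methoxy Group from a Trimethoxyphenyl Compound

The compounds below may be only part of what the source reports. "The series", "measured", "known", "first", "only" and "open" are said of these compounds alone.

Within the data shown here, compound 1 `COc1cc(-c2cc(/C=C/C(=O)c3ccc(N)cc3)[nH]n2)cc(OC)c1OC` is the only compound here with a real number in a functional assay on A549 cells (Homo sapiens) for inhibition, read by sulforhodamine B assay, with a stated time of 48 h; a higher number here means that more compound is tolerated, a lower number that less compound is tolerated: compound 1 gives 86500 nM. For compound 2 `COc1cc(-c2cc(/C=C/C(=O)c3ccc(Cl)c(Cl)c3)[nH]n2)cc(OC)c1OC` the assay reports only a limit: in this assay compound 2 shows > 100000 nM (the limit of > 100000 nM in this assay, at which 1 of the 2 values shown sits). The step of an at least 1.1-fold higher number from compound 1 to compound 2 (0.06 log units; that floor lies within the scatter) changes the group on the carbonyl carbon and gives little guidance. Compound 3 `COc1ccc(-c2cc(/C=C/C(=O)c3ccc(N)cc3)[nH]n2)cc1OC` changes a different part: hydrogen in place of methoxy on an aromatic carbon. Among the measured compounds shown here, no measured step touches that ring, so no direction can be read. Compound 3 is therefore expected near compound 1, at 90000 nM (range 40000 nM to 200000 nM), a step of a 1.0-fold higher number from compound 1 to compound 3 (0.02 log units; within the scatter) that is expected to stay within the scatter.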

Compound 3, concentration lethal to 50% of the cells: 45200 nM
Beside the measured number, compound 3's estimate is 2.0-fold (0.30 log units) above it, and the stated range covers the measured number.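

Among these compounds, this is the first step that touches the methoxy-bearing ring. With hydrogen in place of methoxy on an aromatic carbon, this assay gives a 1.9-fold lower number from compound 1 to compound 3 (0.28 log units; within the scatter), so this one methoxy group can go without a change that stands out from the scatter. No information shown here bears on a cause for this step.

Going by these compounds, whether a hydroxyl group, a fluorine atom or a longer ether chain at this position would move the number remains open. So does the effect of removing either remaining methoxy group.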